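This account rests on a few compounds, and the source may have more. Where it says the series, first, only, none or still open, it means among the compounds named here.

Measured compounds in a functional assay on cells (Cancer cell lines, Homo sapiens) for inhibition, read by MTT assay, with a stated time of 48 h; a lower number here means a stronger inhibitor, a higher number a weaker inhibitor:
- compound 1, `O=C(/C=C/c1ccc(Br)cc1)NNC(=O)c1ccc2c(c1)OCCO2`, gives 2330 nM
- compound 2, `O=C(/C=C/c1ccc(F)cc1)NNC(=O)c1ccc2c(c1)OCCO2`, gives 990 nM
- compound 3, `O=C(/C=C/c1ccccc1[N+](=O)[O-])NNC(=O)c1ccc2c(c1)OCCO2`, gives 890 nM

Compound 1 stands highest of these three numbers in this assay: its nearest neighbour is compound 2, reached by a 2.4-fold lower number from compound 1 to compound 2 (0.37 log units; beyond the scatter), and its furthest is compound 3, reached by a 2.6-fold lower number from compound 1 to compound 3 (0.42 log units; beyond the scatter). Compounds 2 and 3 lie within the scatter of each other, as a 1.1-fold lower number from compound 2 to compound 3 (0.05 log units; within the scatter) shows.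

Compound 4, `O=C(/C=C/c1cccc(F)c1)NNC(=O)c1ccc2c(c1)OCCO2`, has not been measured. It differs from compound 1 in one place: 3-fluorophenyl in place of 4-bromophenyl on a double-bonded chain carbon bound to a double-bonded chain carbon.

Among the measured compounds shown here, the step that bears on this change is the one from compound 1 to compound 2, where a fluoro in place of bromo on an aromatic carbon gave a 2.4-fold lower number from compound 1 to compound 2 (0.37 log units; beyond the scatter). For the measured compounds named here, compound 4 carries the fluorine on a 3-fluorophenyl rather than the 4-fluorophenyl of compound 2, and nothing among the measured compounds shows how that shift alone behaves. A modest lowering of the number is therefore expected in this assay, of about a 1.9-fold lower number from compound 1 to compound 4 (0.29 log units; within the scatter), though a step within the scatter cannot be ruled out. Compound 4 is estimated at 1200 nM, with a range from 550 nM to 2600 nM.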

Compound 4, half-maximal inhibitory concentration: 4110 nM
For compound 4 the middle estimate is 3.4-fold (0.53 log units) below the measured one; the whole stated range lies below it.
By their numbers in this assay, from the lowest: compounds 3 and 2 (each within the scatter of the next); then compounds 1 and 4 (each within the scatter of the next).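

In this assay, moving the fluorine matters at this position: 3-fluorophenyl in place of 4-fluorophenyl gives a 4.2-fold higher number from compound 2 to compound 4 (0.62 log units; beyond the scatter) and so separates two groups that carry the same atoms. The step seen with 4-fluorophenyl therefore does not carry over to every fluorophenyl group, since 3-fluorophenyl in place of 4-bromophenyl gives a 1.8-fold higher number from compound 1 to compound 4 (0.25 log units; within the scatter) and stays within the scatter, while 3-fluorophenyl in place of 2-nitrophenyl gives a 4.6-fold higher number from compound 3 to compound 4 (0.66 log units; beyond the scatter) and goes beyond it. Nothing available explains why the two fluorophenyl groups part in this way.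

The compounds shown leave open how 3-bromophenyl, 4-nitrophenyl or 2-fluorophenyl would read at this place, so the atom and its position on the ring cannot yet be told apart. They also leave open whether a phenyl group bearing an amine or a carboxylic acid would be tolerated here.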